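Dropping one methoxy from the trimethoxyanilide

This account rests on a few compounds, and the source may have more. Where it says the series, first, only, none or still open, it means among the compounds named here.

Compound 1 `COc1cc(NS(=O)(=O)c2ccc(N3CCNC3=O)cc2)cc(OC)c1OC` — 22 nM
Compound 2 `Cc1cccc(NS(=O)(=O)c2ccc(N3CCNC3=O)cc2)c1` — 200 nM
Compound 3 `Cc1ccc(C)c(NS(=O)(=O)c2ccc(N3CCNC3=O)cc2)c1` — 72 nM

In a functional assay on SK-OV-3 cells (Homo sapiens) for antiproliferative activity, read by sulforhodamine B assay, with a stated time of 48 h (a higher number here means a weaker inhibitor, a lower number a stronger inhibitor), compound 1 gives the lowest of the three numbers; compound 3 stands nearest and compound 2 furthest. The new compound 4 `COc1cc(NS(=O)(=O)c2ccc(N3CCNC3=O)cc2)cc(OC)c1` differs from compound 1 by hydrogen in place of methoxy on an aromatic carbon. Among the compounds with values here, the only measured single step, a 2.8-fold lower number from compound 2 to compound 3 (0.44 log units; beyond the scatter), concerns an added methyl and not a removed methoxy, so it bears on this change only loosely, showing that one small substituent on that ring can shift the number modestly. Removing a methoxy from compound 1 is therefore expected to raise the number by a modest amount, a 2.7-fold higher number from compound 1 to compound 4 (0.44 log units; beyond the scatter). Compound 4 is estimated at 60 nM, within a range of 20 nM to 180 nM.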

Compound 4, half-maximal inhibitory concentration: 170 nM
The estimate for compound 4 lay 2.8-fold (0.45 log units) below the measured number; the measured number falls inside the stated range.
By their numbers in this assay, from the lowest: compound 1; then compound 3; then compounds 4 and 2 (each within the scatter of the next).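

In this assay, the methoxy ortho to two methoxy groups and para to a large group proves to matter: replacing it with hydrogen gives a 7.7-fold higher number from compound 1 to compound 4 (0.89 log units; beyond the scatter). Within the data shown here, this is the first measured step that removes a methoxy from this ring, and it shows that the group at this place contributes to the low number of compound 1. Nothing available accounts for the size of this step. The compounds shown leave open whether a hydroxyl, an ethoxy or an amine at this place would keep the number of compound 1 or lose it as hydrogen does.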